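The compounds below may be only part of what the source reports. "The series", "measured", "known", "first", "only" and "open" are said of these compounds alone.

Measured compounds in an assay on HeLa cells for displacement of a labelled ligand from 5-hydroxytryptamine receptor 6 (Homo sapiens), with a stated time of 2 h; a lower number here means a stronger inhibitor, a higher number a weaker inhibitor:
compound 1 `O=S(=O)(c1ccccc1)c1cn(C2CCN(Cc3ccccc3)CC2)c2ccccc12` gives 49 nM
compound 2 `O=S(=O)(c1ccccc1)c1cn(C2CCNCC2)c2ccccc12` gives 91 nM
compound 3 `CN1CCC(n2cc(S(=O)(=O)c3cccc4cccnc34)c3ccccc32)C1` gives 2.8 nM

Compound 2 has the highest number of the three in this assay. Among the measured compounds shown here, its nearest neighbour is compound 1, the step of a 1.9-fold higher number from compound 1 to compound 2 (0.27 log units; within the scatter) lying within the scatter; compound 3, with a different sulfonyl aryl group and a different ring on the aromatic nitrogen, sits furthest away with a much lower number, and no single-point step connects it to compound 2.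

Compound 4 `CCN1CCCC(n2cc(S(=O)(=O)c3ccccc3)c3ccccc32)C1` carries 1-ethylpiperidin-3-yl in place of piperidin-4-yl on an aromatic nitrogen. For the measured compounds named here, the only measured step that bears on this change is the one between compound 1 and compound 2, where removing the benzyl from the ring amine altered the number by a 1.9-fold higher number from compound 1 to compound 2 (0.27 log units; within the scatter), within the scatter. Alkylation of that nitrogen thus has little shown effect, and the shift of the attachment point on the saturated ring is not covered by any measured pair. The step of a 1.8-fold lower number from compound 2 to compound 4 (0.26 log units; within the scatter) is therefore expected to be small, leaning toward a lower number. For compound 4 the estimate in this assay is 50 nM, with a range from 15 nM to 160 nM.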

Compound 4, inhibition constant: 7.3 nM
Beside the measured number, compound 4's estimate is 6.8-fold (0.84 log units) above it; measured number below the stated range.
By their numbers in this assay, from the lowest: compound 3; then compound 4; then compounds 1 and 2 (each within the scatter of the next).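

In this assay, 1-ethylpiperidin-3-yl in place of piperidin-4-yl on the aromatic nitrogen gives a 12-fold lower number from compound 2 to compound 4 (1.10 log units; beyond the scatter). Among the compounds shown here, the earlier step at this place, a 1.9-fold higher number from compound 1 to compound 2 (0.27 log units; within the scatter), showed no change beyond the scatter, so this is the first sign that the number responds to the saturated ring group here. No data shown offer an explanation for the step.

Going by these compounds, the step combines a new attachment point on the ring with an ethyl on the ring nitrogen, so it remains open which of the two carries the lower number; piperidin-3-yl and 1-ethylpiperidin-4-yl would separate them. Also open, on these data alone, is how a longer chain such as propyl on that nitrogen would read in this assay.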